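From phenyl to furan-3-yl on the shared core

The source may report more compounds than this note shows. Statements on the series, on what has been measured and on what is new or still open speak of the compounds shown alone.

compound 1 `CC(=O)c1ccc2[nH]c(-c3ccccc3)nc2c1` gives > 100000 nM as a limit
compound 2 `C/C(=N\NC(N)=O)c1ccc2[nH]c(-c3ccccc3)nc2c1` gives > 100000 nM as a limit

In an ADME assay on BHK-21 cells (Mesocricetus auratus) for cytotoxicity, read by MTT assay (a higher number here means that more compound is tolerated, a lower number that less compound is tolerated), compound 1 gives > 100000 nM as a limit, not a number. Within the data shown here, its standing is therefore only this: the limit of > 100000 nM in this assay, at which 2 of the 2 values shown sit, applies to both compounds measured so far.

Compound 3 `CC(=O)c1ccc2[nH]c(-c3ccoc3)nc2c1` keeps the core of compound 1 and differs by one group: furan-3-yl in place of phenyl on an aromatic carbon is the whole change. Among the measured compounds shown here, the only measured step, a step that the two limits leave unreadable from compound 1 to compound 2 in size terms, involves a different group and gives no size to carry over. For the measured compounds named here, no measured step covers furan-3-yl in place of phenyl. No step beyond the scatter is therefore expected in this assay and the expected step is a number no higher from compound 1 to compound 3 (the limit leaves the size open) in this reading. For compound 3 the estimated value is 100000 nM with an expected range from 40000 nM to 200000 nM and a limit is the likeliest report.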

Compound 3, half-maximal cytotoxic concentration: 98000 nM
Beside the measured number, compound 3's estimate is 1.0-fold (0.01 log units) above it; measured number inside the range.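

Furan-3-yl in place of phenyl, on an aromatic carbon between two ring nitrogen atoms, brings the first value in this assay that is a number and not a limit: compound 3 gives 98000 nM. As far as these compounds go, the step reads an at least 1.0-fold lower number from compound 1 to compound 3 (0.00 log units; that floor lies within the scatter), so nothing beyond the scatter can be claimed for this change, and its full size stays open. The size stays open because one end of the comparison is a limit: the limit of > 100000 nM in this assay, at which 2 of the 3 values shown sit.

The compounds shown leave open whether an amine or a carboxylic acid on the phenyl ring, or a saturated ring such as morpholine at this position, would give a number clearly apart from compound 3 in this assay. Also open, from the compounds shown here alone, is whether furan-3-yl gives a number when combined with the other side group of compound 2.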